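Fluorophenyl sulfonyl side chain: from compound 2 to compound 3

The source may report more compounds than this note shows. Statements on the series, on what has been measured and on what is new or still open speak of the compounds shown alone.

Within the data shown here, in a functional assay on cells (Panel renal (Carcinoma cell lines), Homo sapiens) for inhibition, read by sulforhodamine B assay, with a stated time of 48 h (a higher number here means a weaker inhibitor, a lower number a stronger inhibitor), compound 1 `CN1CCCN(CCNc2nccc(-c3c(-c4cccc(O)c4)nc4sccn34)n2)S1(=O)=O` reads 5980 nM and compound 2 `O=S(=O)(NCCCNc1nccc(-c2c(-c3cccc(O)c3)nc3sccn23)n1)c1cccc(F)c1` reads 2930 nM as the lower of the only two numbers so far. Compound 3 `O=S(=O)(NCCNc1nccc(-c2c(-c3cccc(O)c3)nc3sccn23)n1)c1ccc(F)cc1` is not yet measured. Relative to compound 2, it carries ((4-fluorophenyl)sulfonyl)amino in place of (((3-fluorophenyl)sulfonyl)amino)methyl on a saturated chain carbon, two bonds along the chain from a nitrogen on an aromatic ring.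

Among the measured compounds shown here, only one measured step bears on this change: a 2.0-fold lower number from compound 1 to compound 2 (0.31 log units; beyond the scatter) at the same place. That step is modest, and it exchanged a different end group, so it is only a weak guide here. For the measured compounds named here, no measured pair isolates the new fluorine position or the loss of the methyl link. No step beyond the scatter is therefore expected in this assay, and neither direction is favoured. The expected step is a 1.1-fold higher number from compound 2 to compound 3 (0.05 log units; within the scatter) on this reading. Compound 3 is estimated at 3300 nM with an expected range of 1400 nM to 7500 nM for the measurement to come.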

Compound 3, half-maximal inhibitory concentration: 5380 nM
Beside the measured number, compound 3's estimate is 1.6-fold (0.21 log units) below it; the measured number falls inside the stated range.
By their numbers in this assay, from the lowest: compounds 2, 3 and 1 (each within the scatter of the next, the first and the last beyond it).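

In this assay, ((4-fluorophenyl)sulfonyl)amino in place of (((3-fluorophenyl)sulfonyl)amino)methyl gives a 1.8-fold higher number from compound 2 to compound 3 (0.26 log units; within the scatter) at this position on the saturated chain carbon, so this combined exchange of link and fluorine position is not resolved from repeat-measurement noise. The aromatic sulfonyl end group also no longer stands apart from the six-membered non-aromatic ring of compound 1: the earlier 2.0-fold lower number from compound 1 to compound 2 (0.31 log units; beyond the scatter) lay beyond the scatter, while the new 1.1-fold lower number from compound 1 to compound 3 (0.05 log units; within the scatter) lies within it. Among these compounds, compound 3 therefore goes against any reading that an aromatic sulfonyl end group as such separates this series from compound 1, and the one step beyond the scatter rests on compound 2 alone. No supporting data bear on these readings.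

Going by these compounds, the fluorine position and the methyl link changed together, so their separate contributions remain unknown, and a pair differing only in one of them would be needed to divide the step. Also open, on these data alone, is how this assay responds at this position to a longer chain, or to an amine or a carboxylic acid as the end group.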